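A thiazole amide on the shared core of compound 3

The compounds below may be only part of what the source reports. "The series", "measured", "known", "first", "only" and "open" are said of these compounds alone.

Compound 1, `CCCCNc1nc(N)nc2c1CNCC2`, gives 7.2 uM in an assay on HEK293 cells for agonist activity at Toll-like receptor 8 (Homo sapiens), read by a luciferase reporter, with a stated time of 6 h; a lower number here means that less compound is needed, a higher number that more compound is needed for the effect.
Compound 2, `CCCCNc1nc(N)nc2c1CN(Cc1ccccc1Cl)CC2`, gives 0.05 uM in this assay.
Compound 3, `CCCCNc1nc(N)nc2c1CN(C(=O)c1cnc(C)cn1)CC2`, gives 6.8 uM in this assay.

Compound 3 stands second highest of the three numbers. Compound 1 is nearest to it, within the scatter, and compound 2 is furthest, with a much lower number. Going by the values given here, the single measured step, a 140-fold lower number from compound 1 to compound 2 (2.16 log units; beyond the scatter), concerns a 2-chlorobenzyl entering on an amine nitrogen in a ring and does not bear on the exchange of one heteroaryl for another on a carbonyl carbon. Compound 4, `CCCCNc1nc(N)nc2c1CN(C(=O)c1cscn1)CC2`, differs from compound 3 by 1,3-thiazol-4-yl in place of 5-methylpyrazin-2-yl on a carbonyl carbon. Among the compounds with values here, no measured pair shows what such an exchange does in this assay. Compound 1 and compound 3 lie within the scatter of each other, so the acyl group present in compound 3 has not itself moved the number beyond the scatter. For compound 4 the expected step is a 1.0-fold higher number from compound 3 to compound 4 (0.01 log units; within the scatter), not beyond the scatter. Compound 4 is therefore estimated at 7 uM, within 2 uM to 25 uM.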

Compound 4, minimum effective concentration: 0.5 uM
The estimate for compound 4 lay 14-fold (1.15 log units) above the measured number, outside the stated range (below it).
By their numbers in this assay, from the lowest: compound 2; then compound 4; then compounds 3 and 1 (each within the scatter of the next).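

In this assay the exchange on the carbonyl carbon gives a 14-fold lower number from compound 3 to compound 4 (1.13 log units; beyond the scatter) and so shows that the heteroaryl group at this position matters, which the acyl group of compound 3 alone could not show. Acylation of the amine nitrogen in a ring can thus lower the number, as a 14-fold lower number from compound 1 to compound 4 (1.16 log units; beyond the scatter) makes plain, although the amide compound 4 still lies behind the benzyl compound, with a 10-fold higher number from compound 2 to compound 4 (1.00 log units; beyond the scatter) on that nitrogen. Nothing given here accounts for the difference between 1,3-thiazol-4-yl and 5-methylpyrazin-2-yl.

The compounds shown leave open whether a phenyl or a furan-2-yl on the same carbonyl carbon would stay close to compound 4 or to compound 3. They also leave open whether 1,3-thiazol-4-yl joined through a methylene in place of the carbonyl would approach compound 2.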